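The source may report more compounds than this note shows. Statements on the series, on what has been measured and on what is new or still open speak of the compounds shown alone.

The measured compounds:
Compound 1, `CCOc1ccc(-c2c(C#N)c(N)nc(SCc3ccn[nH]3)c2C#N)cc1`: in an assay on CHO cells for displacement of a labelled ligand from adenosine receptor A3 (Homo sapiens), read by scintillation counting, with a stated time of 120 min, tested at 1 uM (on this read-out lower numbers stand for less inhibition and higher numbers for more inhibition at the one concentration tested (going by the name of the read-out)), compound 1 gives 18%.
Compound 2, `N#Cc1c(N)nc(SCc2cccc(C(N)=O)c2)c(C#N)c1-c1ccc(OCC2CC2)cc1`: compound 2 gives 1%.
Compound 3, `C=CCOc1ccc(-c2c(C#N)c(N)nc(SCc3ccn[nH]3)c2C#N)cc1`: compound 3 gives 13%.

Compound 2 gives the lowest of the three numbers; compound 3 stands higher by a margin beyond the scatter, and compound 1 higher still, also beyond the scatter. Within the data shown here, the only step between compounds that differ in one place, a number 5 percentage points lower from compound 1 to compound 3 (within the scatter), concerns the chain on the aromatic oxygen and lies within the scatter; it leaves the sulfur-bound side untouched.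

The unmeasured compound 4, `N#Cc1c(N)nc(SCn2cncn2)c(C#N)c1-c1ccc(OCC2CC2)cc1`, differs from compound 2 by 1H-1,2,4-triazol-1-yl in place of 3-carbamoylphenyl on a saturated chain carbon bound to a sulfur. Among the measured compounds shown here, no measured step bears directly on this change. Compounds 1 and 3 carry a different group on the saturated chain carbon bound to the sulfur together with a different chain on the aromatic oxygen, and both give higher numbers than compound 2, but they differ from it in two places at once, so their values are only a loose hint. Compound 4 is therefore expected to show a modest rise, a number 9 percentage points higher from compound 2 to compound 4 (within the scatter), of a size that may or may not clear the scatter. For compound 4 the estimate is 10%, with a range from 0% to 25%.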

Compound 4, a percentage reported as inhibition, at one concentration (the size of the read-out at that concentration, not a potency): 1%
For compound 4 the middle estimate is 9 percentage points above the measured one; the measured number falls inside the stated range.
By their numbers in this assay, from the lowest: compounds 2 and 4 (each within the scatter of the next); then compounds 3 and 1 (each within the scatter of the next).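

In this assay, among these compounds, 1H-1,2,4-triazol-1-yl in place of 3-carbamoylphenyl on a saturated chain carbon bound to a sulfur gives no change at the digits printed from compound 2 to compound 4 (within the scatter), the first direct reading of a change at this place with the rest of the molecule held constant. The entering group differs from the leaving one in ring size, hetero atoms and heavy-atom count, yet the pair shows no difference in the read-out, and with both numbers this close to zero a further fall would have little room to appear. No measurement at hand explains this outcome or says what either group does at the receptor.

From the compounds shown here alone, it remains open whether the group on the sulfur-bound carbon of compound 1, paired with the chain on the aromatic oxygen of compound 2, would lift the number, which would separate the contributions of the two places. Also open, going by these compounds, is how the read-out would respond at this place to a 3-carboxyphenyl group, an aminomethyl-bearing phenyl ring or a plain longer alkyl chain.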